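A Change on the Sulfur

The compounds below may be only part of what the source reports. "The series", "measured", "known", "first", "only" and "open" are said of these compounds alone.

In a functional assay on SMMC-7721 cells (Homo sapiens) for inhibition, read by CCK-8 assay, with a stated time of 72 h, tested at 8 uM (on this read-out higher numbers stand for more inhibition of growth at the one concentration tested and lower numbers for less inhibition of growth), compound 1 `Nc1ccccc1NC(=O)/C=C/c1ccc(CSc2cccc(F)c2)cc1` gives 8.25%, and compound 2 `Nc1ccccc1NC(=O)/C=C/c1ccc(CSc2ccc(C(F)(F)F)cn2)cc1` gives 20.1%, the higher of the two numbers. Compound 3 `Nc1ccccc1NC(=O)/C=C/c1ccc(CSc2cccc3ccccc23)cc1` is still unmeasured and carries naphthalen-1-yl in place of 5-(trifluoromethyl)pyridin-2-yl on a sulfur. Among the measured compounds shown here, only one measured step bears on this place: a number 11.9 percentage points higher from compound 1 to compound 2 (beyond the scatter), a modest change beyond the scatter. For the measured compounds named here, no measured compound carries naphthalen-1-yl, so that step gives only a rough guide to size. The group entering compound 3 has rings of carbon only, as does the 3-fluorophenyl of compound 1 at 8.25%, which points weakly downward. The expected change is a number 5.1 percentage points lower from compound 2 to compound 3 (within the scatter), a small fall that stays within the scatter. For compound 3 the estimated value is 15%, with an expected range from 3% to 34%.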

Compound 3, percent growth inhibition at one concentration: 18.3%
For compound 3 the middle estimate is 3.3 percentage points below the measured one; the measured number falls inside the stated range.
By their numbers in this assay, from the lowest: compound 1; then compounds 3 and 2 (each within the scatter of the next).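

In this assay, naphthalen-1-yl in place of 5-(trifluoromethyl)pyridin-2-yl on the sulfur gives a number 1.8 percentage points lower from compound 2 to compound 3 (within the scatter), so the hetero atom and the fluorines of the leaving group are not required to reach this level of inhibition. A group with rings of carbon only does not by that fact alone stay at the level of compound 1: naphthalen-1-yl in place of 3-fluorophenyl gives a number 10.1 percentage points higher from compound 1 to compound 3 (beyond the scatter). No measurement available here explains either step.

Still open, as far as these compounds go, is whether a group carrying an amine or a carboxylic acid on the sulfur, or a saturated cyclohexyl ring there, would move the number beyond that of compound 2 or compound 3. Every compound shown also keeps the sulfur itself, so the effect of an oxygen in its place remains unknown.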